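Sulfoximine to sulfonamide exchange on a piperidine ester core

A few compounds are considered here, and "the series" means these few. Any claim that something is new, unique, unknown or untested is made for them only; others in the source may bear on it.

Measured compounds:
compound 1, `CCOC(=O)[C@@H]1CCCN(S(=O)(=O)c2ccc(S(=N)(=O)N(CC)CC)cc2)C1`, 3600 nM
compound 2, `CCOC(=O)C12CC(CN(S(=O)(=O)c3ccc(S(=O)(=O)N(CC)CC)cc3)C1)C2`, 1200 nM

In a functional assay on BXPC-3 cells (Homo sapiens) for inhibition, read by MTT assay, with a stated time of 7 days (on this read-out higher numbers stand for weaker inhibition and lower numbers for stronger inhibition), compound 1 gives 3600 nM, the highest of the two numbers in hand. Compound 2, built on a different core, gives 1200 nM, a lower number, and the gap between the two lies beyond the scatter. For the measured compounds named here, no single-point step between measured compounds is available to guide the next change.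

Compound 3, `CCCN(CC)S(=O)(=O)c1ccc(S(=O)(=O)N2CCC[C@@H](C(=O)OCC)C2)cc1`, is compound 1 with a group of 9 heavy atoms (5 carbon, 1 nitrogen, 2 oxygen, 1 sulfur; no ring) in place of a group of 8 heavy atoms (4 carbon, 2 nitrogen, 1 oxygen, 1 sulfur; no ring), on an aromatic carbon, placed para to a large group. Going by the values given here, with no measured step of this kind, the expected move is modest: the step from compound 1 to compound 3 is estimated at a 1.8-fold lower number from compound 1 to compound 3 (0.26 log units; within the scatter), toward stronger inhibition but not clearly beyond the scatter. Compound 3 is therefore expected to give about 2000 nM, within a range of 700 nM to 6000 nM.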

Compound 3, half-maximal inhibitory concentration: 300 nM
Beside the measured number, compound 3's estimate is 6.7-fold (0.82 log units) above it, outside the stated range (below it).
By their numbers in this assay, from the lowest: compound 3; then compound 2; then compound 1.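

In this assay, placing ethyl(propyl)sulfamoyl on the aromatic carbon, para to a large group, gives a 12-fold lower number from compound 1 to compound 3 (1.08 log units; beyond the scatter). For the compounds shown here, this is the first single-place step, and it shows that the group at this position can move the read-out well beyond the scatter while the rest of the molecule stays the same. No measurement here explains the size of the step.

The single step changes the group's atoms and its count of hydrogen-bond donors together, from 1 to 0, so the compounds shown do not separate these changes. From the compounds shown here alone, how a butyl chain in place of the propyl chain, or a carboxylic acid in place of the ethyl ester, would read in this assay also remains open.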